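Chloro to methoxy on compound 2

The source may hold more compounds than are shown below. What is called first, only, known or untested is meant among the compounds shown, and "the series" means these compounds.

Measured so far in a functional assay on HT-29 cells (Homo sapiens) for antiproliferative activity, read by MTT assay, with a stated time of 48 h (on this read-out higher numbers stand for weaker inhibition and lower numbers for stronger inhibition), are two compounds:

- compound 1 `COc1ccc(-c2cc(C(=O)OCc3ccccc3)c3cc(C)ccc3n2)cc1` at 17300 nM
- compound 2 `O=C(OCc1ccccc1)c1cc(-c2ccc(Cl)cc2)nc2cc(Cl)c(Cl)cc12` at 48700 nM

Compound 2 holds the higher of the two numbers in this assay, so it shows the weaker inhibition, and its gap to compound 1 lies beyond the scatter. Compound 3 `COc1ccc(-c2cc(C(=O)OCc3ccccc3)c3cc(Cl)c(Cl)cc3n2)cc1` departs from compound 2 by a single change, 4-chlorophenyl to 4-methoxyphenyl, with methoxy in place of chloro on an aromatic carbon, para to a large group (methoxy in place of chloro on an aromatic carbon). Among the compounds with values here, no measured pair shows this change directly. Within the data shown here, the only guide is compound 1 at 17300 nM in this assay, which also carries 4-methoxyphenyl. A modest move toward stronger inhibition is therefore expected, an estimated step (a 1.7-fold lower number from compound 2 to compound 3 (0.24 log units; within the scatter)) that may not clear the scatter. Compound 3 is expected at 28000 nM (range 11000 nM to 65000 nM).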

Compound 3, half-maximal inhibitory concentration: 42200 nM
The estimate for compound 3 lay 1.5-fold (0.18 log units) below the measured number; the measured number falls inside the stated range.
By their numbers in this assay, from the lowest: compound 1; then compounds 3 and 2 (each within the scatter of the next).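

In this assay, within the data shown here, the exchange of chloro for methoxy on the aromatic carbon gives a 1.2-fold lower number from compound 2 to compound 3 (0.06 log units; within the scatter) and so leaves compound 2 and compound 3 indistinguishable, which is the first direct reading of this change. On the dichlorinated core shared by these two compounds, the read-out therefore does not tell 4-chlorophenyl from 4-methoxyphenyl, and carrying the 4-methoxyphenyl group is not enough here to set compound 3 apart from compound 2. No measurement at hand accounts for this result.

As far as these compounds go, it remains open whether the same exchange would read alike on the core of compound 1, which carries a methyl group instead of the two chloro groups. From the compounds shown here alone, it is equally open whether an amine, a carboxylic acid or a longer chain such as butoxy in this place would separate from chloro and methoxy.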